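The compounds below may be only part of what the source reports. "The series", "measured", "known", "first", "only" and "open" are said of these compounds alone.

For the measured compounds named here, in a functional assay on NCI-H1299 cells (Homo sapiens) for inhibition, read by CCK-8 assay, with a stated time of 72 h, tested at 10 uM (a lower number here means less inhibition of growth, a higher number more inhibition of growth at the concentration tested), compound 1 `CN(C)C(=O)c1cc2cnc(Nc3ccc(NC(=O)C4(C(=O)Nc5ccccc5F)CC4)cc3)nc2n1C1CCCC1` gives 89.6%, the top of the three numbers measured so far, though not clear of the scatter. Compound 3 `CN(C)C(=O)c1cc2cnc(Nc3ccc(NC(=O)C4(C(=O)Nc5ccc(F)cc5)CC4)cc3F)nc2n1C1CCCC1` gives 82.6%, which lies within the scatter of compound 1. Compound 2 `Nc1ccc(NC(=O)C2(C(=O)Nc3ccc(F)cc3)CC2)cc1F`, at 59.2%, falls beyond the scatter, lower than both. The next structure, compound 4 `CN(C)C(=O)c1cc2cnc(Nc3ccc(NC(=O)C4(C(=O)Nc5ccc(O)cc5)CC4)cc3)nc2n1C1CCCC1`, keeps the core of compound 1 and carries 4-hydroxyphenyl in place of 2-fluorophenyl on an amide-type nitrogen. Going by the values given here, no measured pair isolates this change, so the data give no direct guide to it. A modest fall in this assay is expected, with a number 14.6 percentage points lower from compound 1 to compound 4 (beyond the scatter) as the estimated step. For compound 4 the estimated value is 75%, within a range from 58% to 88%.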

Compound 4, percent growth inhibition at one concentration: 89.7%
For compound 4 the middle estimate is 14.7 percentage points below the measured one; the whole stated range lies below it.
By their numbers in this assay, from the lowest: compound 2; then compounds 3, 1 and 4 (each within the scatter of the next).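

In this assay, 4-hydroxyphenyl in place of 2-fluorophenyl on the amide-type nitrogen gives a number 0.1 percentage points higher from compound 1 to compound 4 (within the scatter), so this position tolerates the change without a readable loss of growth inhibition. For the compounds shown here, this is the first measured pair to isolate a change at this place, and the entering group's hydrogen-bond donor and acceptor, absent from the group that leaves, produce no readable shift. No evidence at hand bears on this result.

The compounds shown leave open whether the hydroxyl itself matters, since fluorine's removal and the hydroxyl's arrival are not separated. As far as these compounds go, how an amine or a carboxylic acid on that phenyl ring would fare also remains open.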